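A Halogen Swap on the Phenyl Ether Tail

A few compounds are considered here, and "the series" means these few. Any claim that something is new, unique, unknown or untested is made for them only; others in the source may bear on it.

Compound 1 `NC1=NC2(CCOCC2)N(OCCCOc2ccc(F)cc2)C(N)=N1`: 46.6 nM
Compound 2 `Cc1cc(C)cc(OCCCON2C(N)=NC(N)=NC23CCOCC3)c1`: "not determined" (no result reported)
Compound 3 `NC1=NC2(CCOCC2)N(OCCCOc2ccc(Cl)cc2Cl)C(N)=N1`: 7.46 nM

These compounds share one core and differ only in the ring attached through an oxygen on a saturated carbon. In an assay on isolated protein for inhibition of Dihydrofolate reductase (Homo sapiens), read by spectrophotometry, using NADPH, with stated times of 5 s and 6 min (a higher number here means a weaker inhibitor, a lower number a stronger inhibitor), compound 3 gives the lowest number of the two reported; compound 1 sits higher, and compound 2 has no reported result. Among the compounds with values here, the single measured step, a 6.2-fold lower number from compound 1 to compound 3 (0.80 log units; beyond the scatter), shows a modest gain in inhibition. Compound 4 `NC1=NC2(CCOCC2)N(OCCCOc2ccc(Br)cc2)C(N)=N1` carries the next change: 4-bromophenyl in place of 2,4-dichlorophenyl on an oxygen on a saturated carbon. Within the data shown here, no measured step involves 4-bromophenyl, so the step of a 6.2-fold lower number from compound 1 to compound 3 (0.80 log units; beyond the scatter) is the only guide, and a bromine-bearing ring is taken to land between compound 1 and compound 3. Compound 4 is therefore expected to give 20 nM (range 7 nM to 60 nM). The estimated step of a 2.7-fold higher number from compound 3 to compound 4 (0.43 log units; beyond the scatter) is expected to be modest but beyond the scatter.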

Compound 4, half-maximal inhibitory concentration: 32.5 nM
Estimate against measurement, compound 4: 1.6-fold (0.21 log units) below; the measured number falls inside the stated range.
By their numbers in this assay, from the lowest: compound 3; then compounds 4 and 1 (each within the scatter of the next).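

In this assay, swapping only the halogen gives a 1.4-fold lower number from compound 1 to compound 4 (0.16 log units; within the scatter), so at this place bromo and fluoro on the aromatic carbon cannot be told apart. By contrast, a 4.4-fold higher number from compound 3 to compound 4 (0.64 log units; beyond the scatter) shows that, of the three measured rings, 2,4-dichlorophenyl alone stands apart from the others. Nothing available explains this difference.

It remains open whether the lower number of compound 3 goes with having two chlorines or with chlorine itself, as 4-chlorophenyl is not among the compounds shown. Rings bearing an amine or a carboxylic acid are also absent from this set.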